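The source may hold more compounds than are shown below. What is called first, only, known or untested is meant among the compounds shown, and "the series" means these compounds.

Measured in a functional assay on SK-OV-3 cells (Homo sapiens) for cytotoxicity; a higher number here means a weaker inhibitor, a lower number a stronger inhibitor
- compound 1 `C=C/C=C\[C@H](C)[C@H](OC(N)=O)[C@@H](C)[C@H](O)[C@@H](C)C/C(C)=C\[C@H](C)[C@@H](O)[C@@H](C)/C=C\CCc1ccc(Oc2ccccc2)cc1` 10000 nM
- compound 2 `C=C/C=C\[C@H](C)[C@H](OC(N)=O)[C@@H](C)[C@H](O)[C@@H](C)C/C(C)=C\[C@H](C)[C@@H](O)[C@@H](C)/C=C\CCc1ccc(C)c(F)c1` 1000 nM
- compound 3 `C=C/C=C\[C@H](C)[C@H](OC(N)=O)[C@@H](C)[C@H](O)[C@@H](C)C/C(C)=C\[C@H](C)[C@@H](O)[C@@H](C)/C=C\CCc1cc(F)cc(F)c1` 360 nM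

Compound 3 stands lowest of the three, with compound 2 nearest and compound 1 furthest. Compound 4 `C=C/C=C\[C@H](C)[C@H](OC(N)=O)[C@@H](C)[C@H](O)[C@@H](C)C/C(C)=C\[C@H](C)[C@@H](O)[C@@H](C)/C=C\CCc1ccsc1` differs from compound 3 by thiophen-3-yl in place of 3,5-difluorophenyl on a saturated chain carbon, two bonds along the chain from a double-bonded chain carbon. For the measured compounds named here, one measured step bears on this, a 2.8-fold lower number from compound 2 to compound 3 (0.44 log units; beyond the scatter), a modest change at the same place. Going by the values given here, no thiophen-3-yl compound has been measured, so the size stays uncertain. A modest step toward a higher number is expected in this assay, since compound 3 at 360 nM is the lowest so far. The estimate amounts to an expected step of a 1.9-fold higher number from compound 3 to compound 4 (0.29 log units; within the scatter). For compound 4 the estimated value is 700 nM, with an expected range of 220 nM to 2500 nM.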

Compound 4, half-maximal inhibitory concentration: 440 nM
Compound 4: the middle estimate sits 1.6-fold (0.20 log units) above what was measured; the measured number falls inside the stated range.
By their numbers in this assay, from the lowest: compounds 3 and 4 (each within the scatter of the next); then compound 2; then compound 1.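

In this assay, thiophen-3-yl on this saturated chain carbon stays within the scatter of 3,5-difluorophenyl (a 1.2-fold higher number from compound 3 to compound 4 (0.09 log units; within the scatter)), so among these compounds neither fluorine nor a six-membered ring is needed for a number at this level. The five-membered ring also keeps a lower number than 3-fluoro-4-methylphenyl (a 2.3-fold lower number from compound 2 to compound 4 (0.36 log units; beyond the scatter)). Nothing available here accounts for these results. 

As far as these compounds go, it remains open whether thiophen-2-yl, pyridin-3-yl or an amine-bearing aromatic ring would hold this level in place of thiophen-3-yl. From the compounds shown here alone, a longer chain in place of the 2-(thiophen-3-yl)ethyl group is equally open.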